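This account rests on a few compounds, and the source may have more. Where it says the series, first, only, none or still open, it means among the compounds named here.

Within the data shown here, compound 2, `N#C/C(=C\c1ccc(Cl)cc1)C(=O)NCc1ccc(Cl)c(Cl)c1`, is the only member of this small set with a number rather than a limit: in a functional assay on BE(2)-C cells (Homo sapiens) for inhibition, read by MTT assay, with a stated time of 72 h (a higher number here means a weaker inhibitor of growth, a lower number a stronger inhibitor of growth), compound 2 gives 31000 nM. Its neighbour compound 1, `N#C/C(=C\c1ccco1)C(=O)NCc1ccc(Cl)c(Cl)c1`, carries a furan-2-yl group where compound 2 carries a 4-chlorophenyl. In this assay compound 1 gives > 50000 nM, which is a limit of the assay rather than a number. Among the measured compounds shown here, the one measured step, an at least 1.6-fold lower number from compound 1 to compound 2 (0.20 log units; that floor lies within the scatter), therefore sets only a floor, and that floor lies within the usual scatter.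

Compound 3, `COc1ccc(/C=C(\C#N)C(=O)NCc2ccc(Cl)c(Cl)c2)cc1`, differs from compound 2 in one place: methoxy in place of chloro on an aromatic carbon. For the measured compounds named here, no measured step touches this position, so nothing in hand points in either direction. The step is expected to be a 1.0-fold lower number from compound 2 to compound 3 (0.01 log units; within the scatter), that is, none beyond the scatter. Compound 3 is estimated to give 30000 nM in this assay, somewhere between 12000 nM and 80000 nM.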

Compound 3, concentration for 50% growth inhibition: 93000 nM
The estimate for compound 3 lay 3.1-fold (0.49 log units) below the measured number; the measured number lies above the stated range.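

Among these compounds, compound 2 and compound 3 give the first readable step at this spot on the aromatic ring, para to a large group. In this assay, methoxy in place of chloro gives a 3.0-fold higher number from compound 2 to compound 3 (0.48 log units; beyond the scatter), so the group held here does change the result, and in this pair the chloro compound is the stronger inhibitor of growth. Compound 1 has a limit of the assay rather than a number, so its step to compound 3 cannot be read: the limit of > 50000 nM in this assay, at which 1 of the 3 values shown sits.

Only chloro and methoxy have been compared at this position, so the compounds shown leave open how an amine or a carboxylic acid there would read in this assay. A single pair also cannot show whether the same change would have a similar effect on a different core.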